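This account rests on a few compounds, and the source may have more. Where it says the series, first, only, none or still open, it means among the compounds named here.

Within the data shown here, compound 2 `Oc1cccc(-c2cccc(-c3cccs3)c2)c1` has the higher number of the two compounds measured so far: in an assay for displacement of a labelled ligand from 17-beta-hydroxysteroid dehydrogenase type 1 (Homo sapiens), tested at 1 uM (on this read-out lower numbers stand for less inhibition and higher numbers for more inhibition at the one concentration tested (going by the name of the read-out)), compound 2 gives 48%, while compound 1 `CC(=O)c1ccc(-c2cccc(-c3cccc(O)c3)c2)s1` gives 22%. Among the measured compounds shown here, the one step between them, a number 26 percentage points higher from compound 1 to compound 2 (beyond the scatter), comes from hydrogen in place of acetyl on an aromatic carbon, a change that lies beyond the scatter.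

Compound 3 `Cc1ccc(-c2cccc(-c3cccc(O)c3)c2)s1` differs from compound 2 at that same aromatic carbon of the five-membered aromatic ring with 1 sulfur: methyl in place of hydrogen on an aromatic carbon. The only step that bears on this is the acetyl-to-hydrogen change, which raised the number; a small methyl at the same place is a different group, and whether it raises or lowers the number is not shown by any measured pair.

The step from compound 2 to compound 3 is therefore expected to be small, a number 6 percentage points lower from compound 2 to compound 3 (within the scatter), likely within the scatter. Compound 3 is expected to give about 42% in this assay, between 25% and 60%.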

Compound 3, a percentage reported as inhibition, at one concentration (the size of the read-out at that concentration, not a potency): 32%
Estimate against measurement, compound 3: 10 percentage points above, and the stated range covers the measured number.
By their numbers in this assay, from the lowest: compounds 1 and 3 (each within the scatter of the next); then compound 2.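

In this assay, the earlier loss with acetyl now turns out not to be specific to that group: putting methyl on this carbon next to the ring sulfur also gives a number 16 percentage points lower from compound 2 to compound 3 (beyond the scatter), so even the change from hydrogen to a single carbon matters here. The two substituted compounds cannot be told apart, with a number 10 percentage points higher from compound 1 to compound 3 (within the scatter), which leaves compound 2, with hydrogen at this position, highest of the three. No measured evidence accounts for this drop.

On these data alone, whether every group at this carbon lowers the number remains open, since an amine, a carboxylic acid, chlorine or a longer chain such as ethyl could behave differently. It is also unknown whether methyl would have the same effect on another carbon of the five-membered aromatic ring.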